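Isoxazole replacement on the dichloroaryl position of compound 1

The compounds below may be only part of what the source reports. "The series", "measured", "known", "first", "only" and "open" are said of these compounds alone.

Within the data shown here, compound 1 `Cc1cc(C)c(CN2CCc3c(Cl)cc([C@H](CO)[C@H]4CCOC4)c(Cl)c3C2=O)c(=O)[nH]1` is the one compound in this set with a single value in an assay for inhibition of histone-lysine N-methyltransferase EZH2 variant Y641N (Homo sapiens), read by scintillation counting, with a stated time of 60 min, in the presence of a further agent that is not named here; a lower number here means a stronger inhibitor, a higher number a weaker inhibitor: compound 1 gives 0.24 nM. Compound 2 `COc1cc(C)[nH]c(=O)c1CN1CCc2c(Cl)cc(C(OC)C3CCN(C(=O)CO)CC3)c(Cl)c2C1=O` carries the other measurements, and in this assay compound 2 gives 25 nM; 0.13 nM (2 entries); the spread of those entries, (the several entries of compound 2 in this assay, 25 nM; 0.13 nM (2 entries)), shows how far repeat values of this kind can diverge. Compound 3 `Cc1cc(C)c(CN2CCc3c(Cl)cc(-c4c(C)noc4C)c(Cl)c3C2=O)c(=O)[nH]1` has not yet been measured. It differs from compound 1 in one place: a group of 7 heavy atoms (5 carbon, 1 nitrogen, 1 oxygen; one five-membered aromatic ring with 2 hetero atoms) in place of a group of 8 heavy atoms (6 carbon, 2 oxygen; one five-membered non-aromatic ring with 1 hetero atom), on an aromatic carbon. Both keep the shared core and the two chloro groups. Among the measured compounds shown here, no measured pair spans this change, so the direction rests on the structural change alone. A modest loss in this assay is expected, with the step from compound 1 to compound 3 estimated at a 4.2-fold higher number from compound 1 to compound 3 (0.62 log units; beyond the scatter), a shift of roughly the size of the usual scatter. Compound 3 is therefore expected to give about 1 nM, within a range of 0.2 nM to 6 nM.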

Compound 3, inhibition constant: 1.15 nM
Compound 3: middle estimate off by 1.2-fold (0.06 log units), on the low side; low and high end bracket the measured number.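

In this assay, the step at this aromatic carbon is modest: a 4.8-fold higher number from compound 1 to compound 3 (0.68 log units; beyond the scatter). The position therefore accepts 3,5-dimethyl-1,2-oxazol-4-yl in place of the non-aromatic group of compound 1, and compound 3 still gives 1.15 nM, even though the hydrogen-bond donor of the leaving group and its 2 defined stereocentres are gone. This single step rests on few entries, and repeat values in this assay can lie far apart: the several entries of compound 2 in this assay, 25 nM; 0.13 nM (2 entries).

The change swaps the ring and removes the donor in one move. These data do not separate the two. On these data alone, how an amine, a carboxylic acid or a longer chain on the five-membered aromatic ring would fare at this position also remains open.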